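Working notes: stability of the sulfonamide analogue, compound 3

The compounds below may be only part of what the source reports. "The series", "measured", "known", "first", "only" and "open" are said of these compounds alone.

Measured so far:
- Compound 1, `COc1ccc(-c2c(C)nc3c(N4CC[C@@H](NC(=O)Nc5ccccc5)C4)cc(C)nn23)cc1OC`. In an ADME assay on microsomes from liver (Homo sapiens) for metabolic stability, read by LC-MS, with NADPH named in the record, with a stated time of 60 min, tested at 1 uM, in the absence of a further agent (on this read-out lower numbers stand for a less stable compound and higher numbers for a more stable compound), compound 1 gives > 95%, which is a limit of the assay.
- Compound 2, `COc1ccc(-c2c(C)nc3c(N4CC[C@@H](NC(=O)Oc5ccc6ccccc6c5)C4)cc(C)nn23)cc1OC`. In this assay compound 2 gives > 95%, again a limit.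

Compound 1 therefore stands at the limit of this assay, with no number below it to place it more finely; the same holds for every value shown, since (the limit of > 95% in this assay, at which 2 of the 2 values shown sit). Among the measured compounds shown here, the only measured step, a step that the two limits leave unreadable from compound 1 to compound 2, is one that the two limits leave unreadable, so its size is not known.

Compound 3, `COc1ccc(-c2c(C)nc3c(N4CC[C@@H](NS(=O)(=O)c5ccc(Cl)cc5)C4)cc(C)nn23)cc1OC`, differs from compound 1 by (4-chlorophenyl)sulfonyl in place of phenylcarbamoyl on an amine nitrogen. No measured step bears on this change: the step from compound 1 to compound 2 alters the group on the carbonyl carbon and is itself unreadable, so nothing shown sets a direction or size for the step to compound 3 in this assay.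

Compound 3 is therefore expected to give about 88%, with a range of 65% to 100%. The step this estimate implies, a number at least 7 percentage points lower from compound 1 to compound 3 (that floor lies within the scatter), is expected to be small, with a fair chance that compound 3 is again reported only as a limit.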

Compound 3, percent of the compound remaining: > 95%
Compound 3: a limit, no number (the forecaster's own chance of this, stated with the estimate: 55%); middle value at least 7 percentage points away from the limit.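

In this assay compound 3 gives > 95%, which is a limit of the assay. The step from compound 1 to compound 3 therefore cannot be read: the limit of > 95% in this assay, at which 3 of the 3 values shown sit.

The compounds shown leave open how far compound 1, compound 2 and compound 3 differ in this assay, and whether any change on this amine nitrogen lowers the percent remaining.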